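A few compounds are considered here, and "the series" means these few. Any claim that something is new, unique, unknown or untested is made for them only; others in the source may bear on it.

compound 1 `O=C1/C(=C/c2cccnc2)CN(S(=O)(=O)c2ccccc2)C/C1=C\c1ccccc1F`: 8210 nM
compound 2 `O=C1/C(=C/c2cccnc2)CNC/C1=C\c1ccccc1C(F)(F)F`: 5020 nM
compound 3 `O=C1/C(=C/c2cccnc2)CN(S(=O)(=O)c2ccccc2)C/C1=C\c1ccccc1C(F)(F)F`: 5370 nM

All three values come from a functional assay on HepG2 cells (Homo sapiens) for cytotoxicity, read by MTT assay, with a stated time of 24 h; a higher number here means a weaker inhibitor, a lower number a stronger inhibitor. In this set, compound 3 stands at 5370 nM, and the values of the other two compounds cannot be told apart from it. Its closest match is compound 2, as the step of a 1.1-fold higher number from compound 2 to compound 3 (0.03 log units; within the scatter) shows, and this step replaces hydrogen on an amine nitrogen in a ring with phenylsulfonyl. The step to compound 1 is also small: a 1.5-fold lower number from compound 1 to compound 3 (0.18 log units; within the scatter), with trifluoromethyl in place of fluoro on an aromatic carbon.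

Compound 4 `O=C1/C(=C/c2ccncc2)CN(S(=O)(=O)c2ccccc2)C/C1=C\c1ccccc1C(F)(F)F` differs from compound 3 in a single place, with pyridin-4-yl in place of pyridin-3-yl on a double-bonded chain carbon bound to a double-bonded ring carbon. Going by the values given here, neither measured step alters this pyridine group, so the evidence for this change is only indirect, and no measured compound yet carries pyridin-4-yl. Both steps stayed within the scatter, so the expectation in this assay is for no change beyond the scatter, in either direction. The expected step is a 1.1-fold lower number from compound 3 to compound 4 (0.03 log units; within the scatter). The estimate for compound 4 is 5000 nM, with an expected range from 2200 nM to 11000 nM.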

Compound 4, half-maximal inhibitory concentration: 7020 nM
Compound 4: middle estimate off by 1.4-fold (0.15 log units), on the low side; low and high end bracket the measured number.
By their numbers in this assay, from the lowest: compounds 2, 3, 4 and 1 (each within the scatter of the next).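

Going by these compounds alone, replacing pyridin-3-yl with pyridin-4-yl on a double-bonded chain carbon bound to a double-bonded ring carbon gives the first direct reading of this position in this assay, namely a 1.3-fold higher number from compound 3 to compound 4 (0.12 log units; within the scatter). The earlier steps shown here changed only the fluoro or trifluoromethyl group on an aromatic carbon and the group on the ring amine nitrogen, so they could not show whether this pyridine group matters; in this single pair, the two forms cannot be told apart in this assay. There is no measured evidence that could explain this result.

The compounds shown leave open whether a more different group at this place, such as a plain phenyl ring or a phenyl ring carrying a carboxylic acid, would shift the number beyond the scatter. They also leave open whether pyridin-4-yl would give a similar step in a compound with fluoro in place of trifluoromethyl, or with hydrogen in place of phenylsulfonyl on the ring amine nitrogen.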